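The source may hold more compounds than are shown below. What is called first, only, known or untested is meant among the compounds shown, and "the series" means these compounds.

Measured compounds in this series:
compound 1 `O=C(CCc1nnc(-c2ccc(Cl)cc2)o1)c1ccccc1`: 42%
compound 2 `O=C(CCc1nnc(-c2ccc([N+](=O)[O-])cc2)o1)c1ccccc1`: 40.9%
compound 3 `Cc1ccc(C(=O)CCc2nnc(-c3ccccc3Cl)o2)cc1`: 36.2%

In a functional assay on the whole organism (strain Wistar) for inhibition, with Rattus norvegicus as the target, with stated times of 30 min and 2 h, at a dose of 20 mg/kg by the oral route (on this read-out higher numbers stand for more inhibition at the one dose given (going by the name of the read-out) and lower numbers for less inhibition), compound 2 gives 40.9%, the second highest of the three numbers, though its gaps to compound 1 and to compound 3 both lie within the scatter. Among the measured compounds shown here, the only single-point step in the set is a number 1.1 percentage points lower from compound 1 to compound 2 (within the scatter), a change of a different kind from the one considered here. Compound 1 and compound 3 differ in more than one place, so their two values show only that both lie close to compound 2.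

Compound 4 `Cc1ccc(C(=O)CCc2nnc(-c3ccc([N+](=O)[O-])cc3)o2)cc1` differs from compound 2 by methyl in place of hydrogen on an aromatic carbon. For the measured compounds named here, no measured pair isolates this change, so there is no step to lean on; the one step available was within the scatter, and the whole set spans a narrow band. On that basis no step beyond the scatter is expected, and the estimate for compound 4 is a number 0.9 percentage points lower from compound 2 to compound 4 (within the scatter). Compound 4 is therefore expected to give about 40% in this assay, within a range of 30% to 50%.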

Compound 4, a percentage reported as inhibition, in the whole organism at one dose (the size of the read-out at that dose, not a potency): 52%
For compound 4 the middle estimate is 12 percentage points below the measured one, and the stated range ends below it.
By their numbers in this assay, from the lowest: compounds 3, 2, 1 and 4 (each within the scatter of the next, the first and the last beyond it).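

With the nitro group on the other aryl ring held fixed, going from phenyl to 4-methylphenyl gives a number 11.1 percentage points higher from compound 2 to compound 4 (beyond the scatter) in this assay. Among the compounds shown here, this is the first single-place change to move the read-out beyond the scatter, so the ring position para to a large group responds to substitution, even to a single added carbon, at least in this one pair. The data offer no explanation for the step.

For the compounds shown here, it remains open whether the methyl step carries over to a compound with chloro in place of nitro, as the only other methyl-bearing compound, compound 3, differs from the rest in more than one place. Also open, on these data alone, is how this position would respond to a different group, such as methoxy, an amine or a longer alkyl chain.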